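The compounds below may be only part of what the source reports. "The series", "measured", "known", "first", "only" and "open" are said of these compounds alone.

Measured in a toxicity assay on MT4 cells (Homo sapiens) for cytotoxicity, read by MTT assay, with a stated time of 5 days; on this read-out lower numbers stand for higher toxicity in this test and higher numbers for lower toxicity in this test:

- Compound 1 `Cc1cnc(Nc2ccc(C#N)cc2)nc1Nc1c(F)cc(-c2cncnc2)cc1F`: 900 nM
- Compound 2 `Cc1cnc(Nc2ccc(C#N)cc2)nc1Nc1c(F)cc(-c2ccnc(F)c2)cc1F`: 167000 nM
- Compound 3 `Cc1cc(-c2cccc3cc[nH]c23)cc(C)c1Nc1ccnc(Nc2ccc(C#N)cc2)n1`: 1000 nM

Compound 3, at 1000 nM, sits level with compound 1 within the usual scatter and well under compound 2. Compound 4 `Cc1cc(-c2cc(C)c(Nc3ccnc(Nc4ccc(C#N)cc4)n3)c(C)c2)cc(C)n1` carries 2,6-dimethylpyridin-4-yl in place of 1H-indol-7-yl on an aromatic carbon. Within the data shown here, only one measured step bears on this exchange of one aromatic ring for another, and it comes from a different core: a 190-fold higher number from compound 1 to compound 2 (2.27 log units; beyond the scatter). That large step shows that such a swap can matter greatly here, but a single example fixes the direction only weakly, so a moderate rise in this assay is expected. The estimate amounts to a 6.0-fold higher number from compound 3 to compound 4 (0.78 log units; beyond the scatter). Compound 4 is expected at about 6000 nM, within an estimated range of 1000 nM to 60000 nM.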

Compound 4, half-maximal cytotoxic concentration: 2300 nM
For compound 4 the middle estimate is 2.6-fold (0.42 log units) above the measured one; the measured number falls inside the stated range.
By their numbers in this assay, from the lowest: compounds 1 and 3 (each within the scatter of the next); then compound 4; then compound 2.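

Putting 2,6-dimethylpyridin-4-yl in place of 1H-indol-7-yl at this position gives a 2.3-fold higher number from compound 3 to compound 4 (0.36 log units; beyond the scatter) in this assay. The exchange removes a hydrogen-bond donor and adds a hydrogen-bond acceptor, yet the number moves only modestly, upward like the earlier ring exchange on the core of compound 1. Nothing available explains this shift. Still open, on these data alone, is how a non-aromatic group, such as an amine or a carboxylic acid, would behave on this carbon. Also open, as far as these compounds go, is whether 2,6-dimethylpyridin-4-yl would give a similar number on the core of compound 1.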